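The source may hold more compounds than are shown below. What is called first, only, known or untested is meant among the compounds shown, and "the series" means these compounds.

Measured in a functional assay on OVCAR-8 cells (Homo sapiens) for antiproliferative activity; a higher number here means a weaker inhibitor, a lower number a stronger inhibitor:
- compound 1 `CNC(=O)C[C@@H]1C[C@@H](c2ccc(Cl)c(Cl)c2)[C@H](NC(=O)c2cc(-c3c(Cl)cnn3C)c(Cl)o2)CN1`: 1130 nM
- compound 2 `CCC[C@@H]1C[C@@H](c2ccc(Cl)c(Cl)c2)[C@H](NC(=O)c2cc(-c3c(Cl)cnn3C)c(Cl)o2)CN1`: 1620 nM
- compound 3 `Cn1ncc(Cl)c1-c1cc(C(=O)N[C@@H]2CN[C@H](CC(=O)NC3CC3)C[C@H]2c2ccc(Cl)c(Cl)c2)oc1Cl`: 580 nM

Compound 3, at 580 nM, has the lowest number of the three, but only the gap to compound 2 is clear: a 2.8-fold lower number from compound 2 to compound 3 (0.45 log units; beyond the scatter). Its separation from compound 1 is smaller: a 1.9-fold lower number from compound 1 to compound 3 (0.29 log units; within the scatter).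

Compound 4 `Cn1ncc(Cl)c1-c1cc(C(=O)N[C@@H]2CN[C@H](CCO)C[C@H]2c2ccc(Cl)c(Cl)c2)oc1Cl` is the next case. The change is hydroxymethyl in place of cyclopropylcarbamoyl on a saturated chain carbon bound to a saturated ring carbon. The amide is therefore lost from the side chain.

Two measured steps change this same place. Replacing methylcarbamoyl with ethyl gave a 1.4-fold higher number from compound 1 to compound 2 (0.16 log units; within the scatter), while the step most like the present one gave the move noted above from compound 2 to compound 3, the only one beyond the scatter. Among the compounds with values here, no measured compound carries the hydroxyl, so its contribution is unknown. On that basis, a modest rise in the number is expected, close to the size of that step: a 2.1-fold higher number from compound 3 to compound 4 (0.32 log units; beyond the scatter).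

For compound 4 the estimated value in this assay is 1200 nM, with an expected range of 500 nM to 3000 nM.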

Compound 4, half-maximal inhibitory concentration: 610 nM
For compound 4 the middle estimate is 2.0-fold (0.29 log units) above the measured one; the range from low to high includes it.
By their numbers in this assay, from the lowest: compounds 3, 4, 1 and 2 (each within the scatter of the next, the first and the last beyond it).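

In this assay the side chain keeps its number without an amide: hydroxymethyl in place of cyclopropylcarbamoyl gives a 1.1-fold higher number from compound 3 to compound 4 (0.02 log units; within the scatter) and, in place of methylcarbamoyl, a 1.9-fold lower number from compound 1 to compound 4 (0.27 log units; within the scatter) as well, both steps lying within the scatter. The hydroxyl now separates from the chain of compound 2, since hydroxy in place of methyl gives a 2.7-fold lower number from compound 2 to compound 4 (0.42 log units; beyond the scatter), a step beyond the scatter and close in size to a 2.8-fold lower number from compound 2 to compound 3 (0.45 log units; beyond the scatter). Nothing on hand explains why the 2-hydroxyethyl and (cyclopropylcarbamoyl)methyl chains read alike here.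

Open, from the compounds shown here alone, is whether the hydroxyl must stand at this distance from the ring carbon, which a longer chain ending in hydroxy would test. Also open, going by these compounds, is how an amine or a carboxylic acid at the chain end would compare with compound 3 and compound 4.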